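Removing the Side-Chain Amine from an Anilinopyrimidine Amide

The compounds below may be only part of what the source reports. "The series", "measured", "known", "first", "only" and "open" are said of these compounds alone.

Compound 1 `COc1cc(N(C)CCN(C)C)c(NC(=O)c2cccnc2)cc1Nc1nccc(-c2cn(C)c3ccccc23)n1` gives 1750 nM in a functional assay on NCI-H1975 cells (Homo sapiens) for antiproliferative activity, read by MTT assay, with a stated time of 72 h; on this read-out lower numbers stand for stronger inhibition and higher numbers for weaker inhibition.
Compound 2 `COc1cc(N(C)CCN(C)C)c(NC(=O)c2cnccn2)cc1Nc1nccc(-c2cn(C)c3ccccc23)n1` gives 1220 nM in this assay.
Compound 3 `COc1cc(N(C)CCN(C)C)c(NC(=O)c2ncccn2)cc1Nc1nccc(-c2cn(C)c3ccccc23)n1` gives 650 nM in this assay.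

Among the three measured compounds, compound 3 is separated from compound 1 by a step beyond the scatter (a 2.7-fold lower number from compound 1 to compound 3 (0.43 log units; beyond the scatter)), whereas its gap to compound 2 stays within the scatter (a 1.9-fold lower number from compound 2 to compound 3 (0.27 log units; within the scatter)), as does the step between compound 1 and compound 2 (a 1.4-fold lower number from compound 1 to compound 2 (0.16 log units; within the scatter)). Compound 4 `COc1cc(N(C)C)c(NC(=O)c2ncccn2)cc1Nc1nccc(-c2cn(C)c3ccccc23)n1` has not yet been measured. It differs from compound 3 by one change: hydrogen in place of (dimethylamino)methyl on a saturated chain carbon bound to a nitrogen on an aromatic ring. None of the three measured steps touches this part of the molecule; all of them exchange the ring on the carbonyl carbon and leave the amine side chain unchanged. Going by the values given here, the data therefore give no step that bears on the change from compound 3 to compound 4, and no direction can be read from them. For compound 4 the estimate is centred close to compound 3, with a wide range: the expected value is 1000 nM, between 250 nM and 4000 nM. This expectation corresponds to a 1.5-fold higher number from compound 3 to compound 4 (0.19 log units; within the scatter).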

Compound 4, half-maximal inhibitory concentration: 5400 nM
Estimate against measurement, compound 4: 5.4-fold (0.73 log units) below; the whole stated range lies below it.
By their numbers in this assay, from the lowest: compounds 3, 2 and 1 (each within the scatter of the next, the first and the last beyond it); then compound 4.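

Cutting the side chain from (2-(dimethylamino)ethyl)(methyl)amino back to dimethylamino produces in this assay the largest single step in this set, an 8.3-fold higher number from compound 3 to compound 4 (0.92 log units; beyond the scatter) and so exceeds every step seen among the rings on the carbonyl carbon. Going by these compounds alone, the earlier compounds all carried the same side chain, and this result is the first to show that the read-out responds to a change there, at least with pyrimidin-2-yl on the carbonyl carbon. Nothing available explains the step.

The compounds shown leave open whether the terminal amine or the chain itself matters, a question that a 2-methoxyethyl group in place of 2-(dimethylamino)ethyl, or a longer chain ending in dimethylamino, would address. From the compounds shown here alone, it also remains open whether removing (dimethylamino)methyl has a similar effect with pyridin-3-yl or pyrazin-2-yl on the carbonyl carbon.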